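Removing One Ring Chloro from a Benzylpurine Pair

A few compounds are considered here, and "the series" means these few. Any claim that something is new, unique, unknown or untested is made for them only; others in the source may bear on it.

Compound 3 `ClCc1cccc(Cn2cnc3c(Cl)nc(Cl)nc32)c1` and compound 1 `ClCc1cccc(Cn2cnc3c(Cl)ncnc32)c1` were both tested in a functional assay on HOP-92 cells (Homo sapiens) for cytotoxicity, read by sulforhodamine B assay, with a stated time of 48 h; a higher number here means a weaker inhibitor of growth, a lower number a stronger inhibitor of growth. In this assay compound 3 gives 3630 nM, and compound 1 gives 6160 nM. The change between them is hydrogen in place of chloro on an aromatic carbon, and the step is a 1.7-fold higher number from compound 3 to compound 1 (0.23 log units; within the scatter). Compound 2 `ClCc1ccc(Cn2cnc3nc(Cl)nc(Cl)c32)cc1` has the same atoms as compound 3 joined differently; the difference between the two cores is not broken down here. In this assay compound 2 gives "not determined" (no result reported), so no result stands for it. Compound 4 `ClCc1ccc(Cn2cnc3ncnc(Cl)c32)cc1` is not yet measured; it differs from compound 2 by hydrogen in place of chloro on an aromatic carbon, the same change as from compound 3 to compound 1. In this assay the step from compound 2 to compound 4 is expected to be as small as the earlier one. Resting on a 1.7-fold higher number from compound 3 to compound 1 (0.23 log units; within the scatter), compound 4 is expected at about 5500 nM, with a range from 1800 nM to 17000 nM.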

Compound 4, concentration for total growth inhibition: 2510 nM
Compound 4: middle estimate off by 2.2-fold (0.34 log units), on the high side, and the stated range covers the measured number.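

Within the data shown here, with no number standing for compound 2 in this assay, no step from compound 2 to compound 4 can be read. The compounds shown leave open how removing this ring chloro acts on their shared core. No evidence bears on this result.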